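Adding a Third Methoxy to a Styryl Sulfone

The compounds below may be only part of what the source reports. "The series", "measured", "known", "first", "only" and "open" are said of these compounds alone.

The set consists of two measured styryl sulfones and one that has not yet been tested. In a functional assay on H157 cells (Homo sapiens) for antiproliferative activity, read by trypan blue exclusion (on this read-out lower numbers stand for stronger inhibition and higher numbers for weaker inhibition), compound 1 `COc1ccc(CS(=O)(=O)/C=C/c2ccc(OC)c(OC)c2)cc1` is reported only as a limit of the assay, > 20000 nM. Compound 2 `COc1ccc(CS(=O)(=O)/C=C/c2cc(OC)ccc2OC)cc1` also gives only a limit in this assay, > 20000 nM. Going by the values given here, compound 2 therefore stands at the limit rather than at a number, and the limit of > 20000 nM in this assay, at which 2 of the 2 values shown sit, shows that both reported values sit there, so no step between measured compounds can be read as a size.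

Compound 3 `COc1ccc(CS(=O)(=O)/C=C/c2cc(OC)c(OC)cc2OC)cc1` differs from compound 2 in one place: methoxy in place of hydrogen on an aromatic carbon. Since compound 2 has no number in this assay, the change from compound 2 to compound 3 can only become visible if it brings compound 3 below the limit; a shift within the scatter would leave compound 3 reported as a limit too. Compound 3 is expected to give about 15000 nM in this assay, with a plausible range from 3000 nM to 60000 nM. That estimate means a step of an at least 1.3-fold lower number from compound 2 to compound 3 (0.12 log units; that floor lies within the scatter), which is expected to be modest at best.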

Compound 3, half-maximal inhibitory concentration: > 20000 nM
Compound 3 was reported as a limit; the forecaster's own chance of this, stated with the estimate: 65%; middle value at least 1.3-fold (0.12 log units) from the limit.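

Going by these compounds alone, compound 3 is also reported only as a limit in this assay and so no step to compound 3, from compound 2 or from compound 1, can be read as a size: the limit of > 20000 nM in this assay, at which 3 of the 3 values shown sit.

The compounds shown leave open whether methoxy in place of hydrogen on an aromatic carbon changes antiproliferative activity at all.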